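Nitro in place of propyl: next step in the series

The compounds below may be only part of what the source reports. "The series", "measured", "known", "first", "only" and "open" are said of these compounds alone.

Compound 1 `COC(=O)c1cccc(NC(=O)COc2ccc(C)cc2)c1` opens the set. In an assay for inhibition of malate dehydrogenase, cytoplasmic (Homo sapiens), with a stated time of 30 min (a higher number here means a weaker inhibitor, a lower number a stronger inhibitor), compound 1 gives > 40000 nM, which is a limit of the assay and not a number. Compound 2 `CCCc1ccc(OCC(=O)Nc2cccc(C(=O)OC)c2)cc1` carries ethyl in place of hydrogen on a saturated chain carbon bound to an aromatic carbon. In this assay compound 2 gives > 40000 nM, again a limit of the assay rather than a number. The step that the two limits leave unreadable from compound 1 to compound 2 is unreadable because both values sit at the limit of > 40000 nM in this assay, at which 2 of the 2 values shown sit. Compound 2 therefore stands only at a limit in this assay, with no readable step to any other compound shown.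

Compound 3 `COC(=O)c1cccc(NC(=O)COc2ccc([N+](=O)[O-])cc2)c1` is the next member: nitro in place of propyl on an aromatic carbon. Within the data shown here, the only measured step, a step that the two limits leave unreadable from compound 1 to compound 2, is unreadable in size, so no measured step bears readably on this change. In this assay the step expected here is a number no higher from compound 2 to compound 3 (the limit leaves the size open), none beyond the scatter that can be claimed. Compound 3 is estimated at 40000 nM, within 10000 nM to 120000 nM, most likely again reported as a limit.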

Compound 3, half-maximal inhibitory concentration: > 40000 nM
Compound 3 was reported as a limit (the forecaster's own chance of this, stated with the estimate: 75%); the middle value lies on the limit itself.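

In this assay compound 3 gives > 40000 nM, again a limit of the assay and not a number. Neither step to compound 3, from compound 1 or from compound 2, can be read: the limit of > 40000 nM in this assay, at which 3 of the 3 values shown sit.

The compounds shown leave open whether any group at this place on the shared core gives a readable value in this assay.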